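The source may report more compounds than this note shows. Statements on the series, on what has been measured and on what is new or still open speak of the compounds shown alone.

Measured in a functional assay on VCaP cells (Homo sapiens) for antiproliferative activity, read by propidium iodide staining, with a stated time of 96 h; on this read-out lower numbers stand for stronger inhibition and higher numbers for weaker inhibition:
- compound 1 `CC(O)(CSc1ccc(S(F)(F)(F)(F)F)cc1)C(=O)Nc1ccc(C#N)cc1C(F)(F)F`: 20500 nM
- compound 2 `CC(O)(CSc1ccc(S(F)(F)(F)(F)F)cc1)C(=O)Nc1ccc(S(F)(F)(F)(F)F)cc1`: 28000 nM
- compound 3 `CC(O)(CSc1ccc(F)cc1)C(=O)Nc1cccc(S(F)(F)(F)(F)F)c1`: 21900 nM

All three values lie within the scatter of one another, so compound 3, at 21900 nM, stands level with the other two. Compound 4 `CC(O)(CSc1ccccc1C(F)(F)F)C(=O)Nc1cccc(S(F)(F)(F)(F)F)c1` has 2-(trifluoromethyl)phenyl in place of 4-fluorophenyl on a sulfur. Among the compounds with values here, no measured pair isolates this change. Compound 1 at 20500 nM and compound 3 at 21900 nM carry different groups on that sulfur, yet their values do not separate, so no step beyond the scatter is expected in this assay. The expected step is a 1.1-fold lower number from compound 3 to compound 4 (0.04 log units; within the scatter). Compound 4 is estimated at 20000 nM, with an expected range from 9000 nM to 45000 nM.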

Compound 4, half-maximal inhibitory concentration: 21000 nM
Compound 4: the middle estimate sits 1.1-fold (0.02 log units) below what was measured; the range from low to high includes it.
By their numbers in this assay, from the lowest: compounds 1, 4, 3 and 2 (each within the scatter of the next).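

The step in this assay is a 1.0-fold lower number from compound 3 to compound 4 (0.02 log units; within the scatter) for 2-(trifluoromethyl)phenyl in place of 4-fluorophenyl on a sulfur. This is the only pair shown that differs in one place, and it shows that this exchange at this position leaves the value level. No supporting measurement bears on this result. As far as these compounds go, whether a pyridine ring or a carboxylic acid on the ring at this sulfur would separate from these values remains open. So does whether any single change elsewhere on the shared core would do so.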